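The compounds below may be only part of what the source reports. "The series", "measured", "known", "first", "only" and "open" are said of these compounds alone.

In a functional assay on BXPC-3 cells (Homo sapiens) for antiproliferative activity, read by MTT assay, with a stated time of 24 h (a higher number here means a weaker inhibitor, a lower number a stronger inhibitor), compound 2 `CCn1c(C(=O)N[C@@H](C)C(=O)O)ccc1C(CC)(CC)c1ccc(OCS(=O)(=O)c2ccccc2)c(C)c1` gives 20800 nM, the higher of the two numbers, and compound 1 `CCn1c(C(=O)N[C@H](CO)C(C)C)ccc1C(CC)(CC)c1ccc(OCS(=O)(=O)c2ccccc2)c(C)c1` gives 7720 nM. Within the data shown here, the only measured step, a 2.7-fold higher number from compound 1 to compound 2 (0.43 log units; beyond the scatter), is modest but beyond the scatter. Compound 3 `CCn1c(C(=O)N[C@@H](C(=O)O)C(C)C)ccc1C(CC)(CC)c1ccc(OCS(=O)(=O)c2ccccc2)c(C)c1` differs from compound 2 by 1-carboxy-2-methylpropyl in place of 1-carboxyethyl on an amide-type nitrogen, with 1-carboxy-2-methylpropyl in place of 1-carboxyethyl on an amide-type nitrogen. That measured step changed more than this one does, so it bears only in part, and only a small move toward a lower number is expected, a 1.5-fold lower number from compound 2 to compound 3 (0.17 log units; within the scatter). For compound 3 the estimated value is 14000 nM, with an expected range of 6500 nM to 30000 nM.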

Compound 3, half-maximal inhibitory concentration: 13900 nM
The estimate for compound 3 lay 1.0-fold (0.00 log units) above the measured number; the range from low to high includes it.
By their numbers in this assay, from the lowest: compounds 1, 3 and 2 (each within the scatter of the next, the first and the last beyond it).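

In this assay, lengthening 1-carboxyethyl to 1-carboxy-2-methylpropyl on the amide-type nitrogen gives a 1.5-fold lower number from compound 2 to compound 3 (0.18 log units; within the scatter), so this change does not separate the two acids. With the branched chain kept, replacing 1-(hydroxymethyl)-2-methylpropyl with 1-carboxy-2-methylpropyl gives a 1.8-fold higher number from compound 1 to compound 3 (0.26 log units; within the scatter), so this pair does not repeat the gap seen beyond the scatter between compounds 1 and 2. No measurement here accounts for either result. Still open, from the compounds shown here alone, is how an amine in place of the carboxylic acid, or a longer chain on this nitrogen, would read in this assay.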